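This account rests on a few compounds, and the source may have more. Where it says the series, first, only, none or still open, it means among the compounds named here.

Working notes on the series, values in a functional assay on K562 cells (Homo sapiens) for inhibition, read by trypan blue exclusion, with a stated time of 72 h; a lower number here means a stronger inhibitor, a higher number a weaker inhibitor
- compound 1 `Cn1c(=O)c(S(=O)(=O)c2ccc(C(=O)O)cc2)cc2cnc(Nc3ccc4[nH]ccc4c3)nc21` gives 5000 nM
- compound 2 `CN1CCN(c2ccc(Nc3ncc4cc(S(=O)(=O)c5ccc(F)cc5F)c(=O)n(C)c4n3)cc2)CC1` gives 5000 nM
- compound 3 `Cn1c(=O)c(S(=O)(=O)Cc2ccc(F)cc2F)cc2cnc(Nc3ccc4[nH]ccc4c3)nc21` gives 1000 nM

Compound 3 holds the lowest of the three numbers. Going by the values given here, compound 2 stands higher, but no single-place step links it to compound 3.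

The next compound is compound 4 `Cn1c(=O)c(S(=O)(=O)c2ccc(F)cc2)cc2cnc(Nc3ccc4[nH]ccc4c3)nc21`, and the change is 4-fluorophenyl in place of 2,4-difluorobenzyl on a sulfonyl sulfur in which 4-fluorophenyl takes the place of 2,4-difluorobenzyl on a sulfonyl sulfur.

Among the compounds with values here, the one measured step bearing on this is a 5.0-fold lower number from compound 1 to compound 3 (0.70 log units; beyond the scatter) for 2,4-difluorobenzyl in place of 4-carboxyphenyl on a sulfonyl sulfur, a modest step. Within the data shown here, compound 4 gives up 2,4-difluorobenzyl as well, but carries 4-fluorophenyl rather than 4-carboxyphenyl, and no measured pair compares those two groups. Part or most of that step is therefore expected to be lost in this assay and the number to rise. The expected change is a 2.5-fold higher number from compound 3 to compound 4 (0.40 log units; beyond the scatter) in that direction. The estimate for compound 4 is 2500 nM (expected range 900 nM to 7000 nM).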

Compound 4, half-maximal inhibitory concentration: 200 nM
The estimate for compound 4 lay 13-fold (1.10 log units) above the measured number; measured number below the stated range.
By their numbers in this assay, from the lowest: compound 4; then compound 3; then compounds 1 and 2 (each within the scatter of the next).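

In this assay, the sulfonyl sulfur carries an aromatic carbon in compound 4 without any penalty: a 5.0-fold lower number from compound 3 to compound 4 (0.70 log units; beyond the scatter), for 4-fluorophenyl in place of 2,4-difluorobenzyl, so the earlier gain did not depend on keeping 2,4-difluorobenzyl. The larger effect at this position belongs to the substituent on the aromatic ring, with a 25-fold lower number from compound 1 to compound 4 (1.40 log units; beyond the scatter), for fluoro in place of carboxy on an aromatic carbon. Nothing available explains either step.

As far as these compounds go, the step to compound 4 removes a carbon and a fluorine together, so their separate contributions remain open, and 4-fluorobenzyl on the same sulfur would divide them. From the compounds shown here alone, whether fluoro itself matters also remains open, since a plain phenyl, or an amine on the ring in its place, would test that.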